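This account rests on a few compounds, and the source may have more. Where it says the series, first, only, none or still open, it means among the compounds named here.

Measured so far:
- compound 1, `COc1ccc(Br)cc1CCc1c(F)cccc1C(=O)/N=C(\N)NCCC1CCCCC1`: 2600 nM
- compound 2, `CCN(CC)CCCC(C)/N=C(/N)NC(=O)c1cccc(F)c1CCc1ccc2ccccc2c1`: 690 nM
- compound 3, `COc1ccc(Br)cc1CCc1c(F)cccc1C(=O)/N=C(\N)NCCCCN(C)Cc1ccccc1`: 5.1 nM

In an assay for binding affinity to Melanocortin receptor 4 (Homo sapiens) (a higher number here means a weaker inhibitor, a lower number a stronger inhibitor), compound 2 gives 690 nM, the second highest of the three numbers. Its nearest neighbour is compound 1, whose number is higher, and the furthest is compound 3, whose number is far lower; both of these gaps lie beyond the usual scatter.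

Compound 4, `CCN(CC)CCCC(C)/N=C(/N)NC(=O)c1cccc(F)c1CCc1cccc2ccccc12`, is built from the same atoms as compound 2 but joined differently: naphthalen-1-yl in place of naphthalen-2-yl on a saturated chain carbon, two bonds along the chain from an aromatic carbon. For the measured compounds named here, the only measured step in this set, a 510-fold lower number from compound 1 to compound 3 (2.71 log units; beyond the scatter), concerns a different part of the molecule, the amine end of the chain, and so says nothing direct about moving the attachment point of the naphthalene. Going by the values given here, no measured pair here varies the naphthalene position, so there is no basis for expecting a large shift in either direction.

Compound 4 is therefore estimated to sit close to compound 2 in this assay, with a step of a 1.3-fold higher number from compound 2 to compound 4 (0.12 log units; within the scatter) that may stay within the scatter. The expected value for compound 4 is 900 nM, with a range from 250 nM to 3200 nM.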

Compound 4, inhibition constant: 89 nM
Estimate against measurement, compound 4: 10-fold (1.00 log units) above, and the stated range ends above it.
By their numbers in this assay, from the lowest: compound 3; then compound 4; then compound 2; then compound 1.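

In this assay, moving the attachment point on the naphthalene gives a 7.8-fold lower number from compound 2 to compound 4 (0.89 log units; beyond the scatter), so this position is sensitive to how the group is joined, not only to which atoms it contains: naphthalen-1-yl and naphthalen-2-yl have the same atoms and the same counts of rings, hydrogen-bond donors and hydrogen-bond acceptors. The earlier step, a 510-fold lower number from compound 1 to compound 3 (2.71 log units; beyond the scatter), showed only that the amine end of the molecule matters, whereas this pair shows that the group on the saturated chain carbon, two bonds along the chain from an aromatic carbon, also changes the number beyond the scatter, though by a modest step. Nothing measured here accounts for the difference between the two attachment points, so the result stands as an observation without an explanation.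

On these data alone, it remains open whether naphthalen-1-yl would give a similar step on a compound with the benzyl(methyl)amino chain of compound 3, whose 5.1 nM is still lower than the value of compound 4. It is also unknown how a smaller plain phenyl group, or a quinolin-4-yl group with a ring nitrogen, would behave in the same place.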